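The source may report more compounds than this note shows. Statements on the series, on what has been measured and on what is new or still open speak of the compounds shown alone.

The four compounds share one core, a central ring carrying two aryl arms, and are compared in a functional assay on MT4 cells (Homo sapiens) for cytotoxicity, read by MTT assay, with a stated time of 5 days; on this read-out higher numbers stand for lower toxicity in this test and lower numbers for higher toxicity in this test. Compound 1 `Cc1cc(-c2ccc(C#N)c(F)c2)ccc1Oc1ccnc(Nc2ccc(C#N)cc2)n1` carries a methyl group on the middle aromatic ring of one arm. In this assay compound 1 gives > 296000 nM, which is a limit of the assay rather than a measured number. Among the three values available, the result for compound 1 sits at the limit of > 296000 nM in this assay, at which 1 of the 3 values shown sits, so compound 1 is known only as one of the least toxic members here. Compound 2 `N#Cc1ccc(Nc2nccc(Nc3ccc(-c4ccc(C#N)cc4)cc3F)n2)cc1`, in which an amine rather than an ether links the arm to the core, gives 308000 nM in this assay. Compound 3 `N#Cc1ccc(Nc2nccc(Oc3ccc(-c4ccc(C#N)c(Cl)c4)cc3Cl)n2)cc1`, which carries chloro groups at two positions of the same arm, gives 14900 nM in this assay, a clearly more toxic reading than the other two.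

Compound 4 `N#Cc1ccc(Nc2nccc(Oc3ccc(-c4ccc(C#N)c(F)c4)cc3F)n2)cc1` is reached from compound 1 by fluoro in place of methyl on an aromatic carbon, so that compound 4 carries fluoro at both positions where compound 3 carries chloro. Among the compounds with values here, no step between two measured compounds of this exact kind is available. Compound 3 shows that halogens at these positions can coincide with markedly higher toxicity, so a moderate move toward higher toxicity is expected from compound 1 to compound 4, an at least 2.9-fold lower number from compound 1 to compound 4 (0.47 log units; beyond the scatter), while compound 4 is expected to stay well short of compound 3. Compound 4 is therefore expected to give about 100000 nM in this assay, with a range from 25000 nM to 300000 nM.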

Compound 4, half-maximal cytotoxic concentration: > 294000 nM
Compound 4: only a limit was reported; the forecaster's own chance of this, stated with the estimate: 30%; at least 2.9-fold (0.46 log units) between middle value and limit.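

Compound 4 gives > 294000 nM in this assay, which is a limit of the assay and not a number. Compound 1 also stands at a limit, so the step between compound 1 and compound 4 cannot be read. Going by these compounds, whether fluoro in place of methyl changes toxicity in this test at all, and by how much, stays open.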